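Swapping the pendant phenyl substituents on a shared core

This account rests on a few compounds, and the source may have more. Where it says the series, first, only, none or still open, it means among the compounds named here.

The three measured compounds share one core and differ only in the group on the pendant phenyl ring. Compound 1 `CCCS(=O)(=O)Nc1ccc(F)c(C(=O)c2n[nH]c3ncc(-c4ccccc4OC)cc23)c1F` carries a methoxy there and in an assay for binding affinity to dual specificity mitogen-activated protein kinase kinase 4 (Homo sapiens), read by KINOMEscan, tested at 100 nM (a higher number here means a weaker effect of the compound at the concentration tested, a lower number a stronger effect), compound 1 gives 1.9%. Compound 2 `CCCS(=O)(=O)Nc1ccc(F)c(C(=O)c2n[nH]c3ncc(-c4ccccc4O)cc23)c1F`, with a hydroxy, gives in this assay 9%, a change of a number 7.1 percentage points higher from compound 1 to compound 2 (within the scatter). Compound 3 `CCCS(=O)(=O)Nc1ccc(F)c(C(=O)c2n[nH]c3ncc(-c4ccccc4N)cc23)c1F`, with an amino group, gives in this assay 23%; it stands highest of the three numbers, the steps being a number 21.1 percentage points higher from compound 1 to compound 3 (beyond the scatter) and a number 14 percentage points higher from compound 2 to compound 3 (beyond the scatter).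

Compound 4 `CCCS(=O)(=O)Nc1ccc(F)c(C(=O)c2n[nH]c3ncc(-c4ccc(Cl)c(C(F)(F)F)c4)cc23)c1F` is the next case: 4-chloro-3-(trifluoromethyl)phenyl in place of 2-aminophenyl on an aromatic carbon. The steps from compound 1 and compound 2 to compound 3 bear on this, since each also replaced the single substituent on the pendant ring, and both were modest yet beyond the scatter. They show that the number moves with that substituent, and that the group without a donor, in compound 1, gave the lowest number. On that ground a modest step downward is expected for compound 4, about a number 11 percentage points lower from compound 3 to compound 4 (beyond the scatter), though the entering group differs in kind and number of substituents from anything measured, so the uncertainty is wide. In this assay compound 4 is therefore estimated at 12%, within a range from 1% to 40%.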

Compound 4, a percentage reported as activity, at one concentration (the size of the read-out at that concentration, not a potency): 15%
Compound 4: middle estimate off by 3 percentage points, on the low side; measured number inside the range.
By their numbers in this assay, from the lowest: compounds 1, 2, 4 and 3 (each within the scatter of the next, the first and the last beyond it).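

In this assay, among these compounds, the position accepts 4-chloro-3-(trifluoromethyl)phenyl, with 11 heavy atoms against the 7 of 2-aminophenyl, without a clear separation from two of the earlier compounds: the steps are a number 8 percentage points lower from compound 3 to compound 4 (within the scatter) and a number 6 percentage points higher from compound 2 to compound 4 (within the scatter). The absence of a hydrogen-bond donor on the pendant ring is not enough to give the lowest number, since compound 4 has none, like compound 1, and yet the step is a number 13.1 percentage points higher from compound 1 to compound 4 (beyond the scatter), so compound 4 goes against the link that the first three compounds suggested between a group without a donor and the lowest number. No measurement here accounts for these steps, and the difference between the 2-methoxyphenyl group and the entering group stays unexplained.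

From the compounds shown here alone, the entering group differs from the earlier ones in its chlorine and its trifluoromethyl at once, so the share of each in the number remains open. A phenyl ring bearing chlorine alone, trifluoromethyl alone or no substituent at all would separate these contributions, and an ethoxy group in place of the methoxy of compound 1 would test how far that group can be extended.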